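The compounds below may be only part of what the source reports. "The series", "measured", "known", "first", "only" and "open" are said of these compounds alone.

Measured compounds:
compound 1 `O=S(=O)(Nc1ccc(F)c(Cl)c1)c1ccc(-c2cnc(C3CC3)o2)cc1` gives 260 nM in a functional assay on cells (leukaemia cell line, Homo sapiens) for inhibition, read by sulforhodamine B assay, with a stated time of 48 h; a higher number here means a weaker inhibitor of growth, a lower number a stronger inhibitor of growth
compound 2 `Cc1cc(NS(=O)(=O)c2ccc(-c3cnc(C4CC4)o3)cc2)ccc1Cl` gives 216 nM in this assay
compound 3 `Cc1ccc(Cl)c(NS(=O)(=O)c2ccc(-c3cnc(C4CC4)o3)cc2)c1` gives 48.8 nM in this assay

The three measured compounds share the core of compound 2 and differ only in the aryl group on a sulfonamide nitrogen. Compound 2 stands second highest of the three numbers. Its nearest neighbour is compound 1, and the step of a 1.2-fold lower number from compound 1 to compound 2 (0.08 log units; within the scatter) lies within the scatter, so the two cannot be placed in order. Its furthest neighbour is compound 3, reached by a 4.4-fold lower number from compound 2 to compound 3 (0.65 log units; beyond the scatter), a modest step beyond the scatter; the step of a 5.3-fold lower number from compound 1 to compound 3 (0.73 log units; beyond the scatter) is of similar size and direction.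

Compound 4 `Cc1cc(F)cc(NS(=O)(=O)c2ccc(-c3cnc(C4CC4)o3)cc2)c1` is not yet measured. It differs from compound 2 in one place: 3-fluoro-5-methylphenyl in place of 4-chloro-3-methylphenyl on a sulfonamide nitrogen. Among the compounds with values here, no measured step involves 3-fluoro-5-methylphenyl. The step that most resembles this change, a swap of one halogen-bearing phenyl for another at the same nitrogen in a 1.2-fold lower number from compound 1 to compound 2 (0.08 log units; within the scatter), stayed within the scatter. The larger steps to compound 3 concern 2-chloro-5-methylphenyl, which compound 4 does not carry, so they give no direct guide. Compound 4 is therefore expected to move by about a 1.2-fold higher number from compound 2 to compound 4 (0.06 log units; within the scatter), that is, no step beyond the scatter. Compound 4 is estimated at 250 nM, with a range from 100 nM to 650 nM.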

Compound 4, concentration for 50% growth inhibition: 138 nM
Estimate against measurement, compound 4: 1.8-fold (0.26 log units) above; the measured number falls inside the stated range.
By their numbers in this assay, from the lowest: compound 3; then compounds 4, 2 and 1 (each within the scatter of the next).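

Set against 4-chloro-3-methylphenyl, the 3-fluoro-5-methylphenyl group gives a 1.6-fold lower number from compound 2 to compound 4 (0.19 log units; within the scatter) in this assay, and set against 3-chloro-4-fluorophenyl it gives a 1.9-fold lower number from compound 1 to compound 4 (0.28 log units; within the scatter) at the same sulfonamide nitrogen, so an aryl group without chlorine stays within the scatter of two that carry it. The 2-chloro-5-methylphenyl group remains apart, with a 2.8-fold higher number from compound 3 to compound 4 (0.45 log units; beyond the scatter) in this comparison, and compound 3 is now the strongest inhibitor of growth of the four, its steps to all three others being beyond the scatter. Since the names of both groups carry 5-methyl, that methyl group is not enough by itself to reach the number of compound 3.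

The compounds shown leave open whether the number of compound 3 would hold with 2-fluoro-5-methylphenyl or 2-methoxy-5-methylphenyl on the sulfonamide nitrogen. They also leave open whether an aryl group carrying a carboxylic acid or an amine would stay within the scatter of compounds 1, 2 and 4. No measurement given here accounts for the separation of compound 3 from the other three.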